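The source may report more compounds than this note shows. Statements on the series, on what has been measured and on what is new or still open speak of the compounds shown alone.

Measured compounds in a functional assay on A549 cells (Homo sapiens) for antiproliferative activity, read by MTT assay, with a stated time of 72 h; a lower number here means a stronger inhibitor, a higher number a weaker inhibitor:

- compound 1 `COc1cc2c(Oc3c(F)cc(NC(=O)NN4C(=O)CCSC4c4c(F)cccc4F)cc3F)ccnc2cc1OCCCN1CCCC1`: 400 nM
- compound 2 `COc1cc2c(Oc3c(F)cc(NC(=O)NN4C(=O)CSC4c4c(F)cccc4F)cc3F)ccnc2cc1OCCCN1CCC(C)CC1`: 970 nM
- compound 3 `COc1cc2c(Oc3c(F)cc(NC(=O)NN4C(=O)CSC4c4c(F)cccc4F)cc3F)ccnc2cc1OCCCN1CCC(N2CCCCC2)CC1`: 380 nM

Among these three numbers compound 1 stands second highest. Compound 3 gives 380 nM, a value that lies within the scatter of the value of compound 1. Compound 2 gives 970 nM, a higher number that lies beyond the scatter.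

Compound 4 `COc1cc2c(Oc3c(F)cc(NC(=O)NN4C(=O)CCSC4c4c(F)cccc4F)cc3F)ccnc2cc1OCCCN1C[C@H]2CCCC[C@H]2C1` differs from compound 1 at the far end of the chain that hangs from the shared core: a group of 9 heavy atoms (8 carbon, 1 nitrogen; one five-membered non-aromatic ring with 1 hetero atom, one six-membered non-aromatic ring of carbon only) in place of a group of 5 heavy atoms (4 carbon, 1 nitrogen; one five-membered non-aromatic ring with 1 hetero atom), on a saturated chain carbon, three bonds along the chain from an oxygen on an aromatic ring. Among the measured compounds shown here, the only measured step that touches this end of the chain is the one from compound 2 to compound 3, where a piperidin-1-yl replaced a methyl on a saturated ring carbon and gave a 2.6-fold lower number from compound 2 to compound 3 (0.41 log units; beyond the scatter), a modest shift. That step enlarged the amine-bearing group, as the change from compound 1 to compound 4 also does, though the two changes are not the same and the cores of compound 2 and compound 3 differ from that of compound 1 by one ring atom. On that slim basis the expected step from compound 1 to compound 4 in this assay is small, a 1.3-fold lower number from compound 1 to compound 4 (0.10 log units; within the scatter), if anything toward a lower number. Compound 4 is therefore estimated to give 320 nM, with a likely range from 140 nM to 800 nM.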

Compound 4, half-maximal inhibitory concentration: 3610 nM
The estimate for compound 4 lay 11-fold (1.05 log units) below the measured number; measured number outside the range, above it.
By their numbers in this assay, from the lowest: compounds 3 and 1 (each within the scatter of the next); then compound 2; then compound 4.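

In this assay, putting the group of 9 heavy atoms in place of pyrrolidin-1-yl on the saturated chain carbon gives a 9.0-fold higher number from compound 1 to compound 4 (0.96 log units; beyond the scatter) and leaves compound 4 with the highest number of the four compounds. The far end of the chain is therefore not a spot where any larger amine group leaves the number unchanged, and enlarging the group here does not have one fixed outcome: the step of a 2.6-fold lower number from compound 2 to compound 3 (0.41 log units; beyond the scatter) goes against this result, although it starts from a different group on a core that differs by one ring atom. Nothing measured here explains why the number rose.

The compounds shown do not separate the contribution of the added six-membered carbon ring from that of the 2 defined stereocentres, so the mirror-image arrangement of compound 4 remains an open comparison, as do simple amines such as dimethylamino, piperidin-1-yl or morpholin-4-yl at this end of the chain on the core of compound 1. Going by these compounds, it also remains open whether the group of 9 heavy atoms would raise the number to the same extent on the core of compound 2.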